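The compounds below may be only part of what the source reports. "The series", "measured", "known", "first", "only" and "open" are said of these compounds alone.

Compounds measured in a functional assay on NCI-H460 cells (Homo sapiens) for inhibition, read by MTT assay, with a stated time of 24 h, tested at 10 ug/mL; on this read-out lower numbers stand for less inhibition of growth and higher numbers for more inhibition of growth at the one concentration tested:

Compound 1 `CC(=O)SCCC(CCCCC(=O)Nc1ccccc1)SC(C)=O` gives 14.2%.
Compound 2 `CC(=O)SCCC(CCCCC(=O)Nc1ccccc1Cl)SC(C)=O` gives 11.4%.
Compound 3 `O=C(CCCCC(CCSC(=O)c1ccccc1)SC(=O)c1ccccc1)Nc1ccccc1` gives 11.4%.

Compound 1 and compound 2 differ by one change, (chloro in place of hydrogen on an aromatic carbon), and that change made a step of a number 2.8 percentage points lower from compound 1 to compound 2 (within the scatter). Compound 3 carries a different core; how its core differs from that of compound 1 is not broken down here, and compound 3 and compound 2 stand level at the digits given. Compound 4 `O=C(CCCCC(CCSC(=O)c1ccccc1)SC(=O)c1ccccc1)Nc1ccccc1Cl` has not yet been tested. It differs from compound 3 by chloro in place of hydrogen on an aromatic carbon, the same change that separates compound 1 from compound 2. Because the step of a number 2.8 percentage points lower from compound 1 to compound 2 (within the scatter) stayed within the scatter, the step from compound 3 to compound 4 is expected to be a number 1.4 percentage points lower from compound 3 to compound 4 (within the scatter). Compound 4 is estimated to give 10% in this assay.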

Compound 4, percent growth inhibition at one concentration: 12.1%
For compound 4 the middle estimate is 2.1 percentage points below the measured one; low and high end bracket the measured number.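

In this assay, putting chloro in place of hydrogen on an aromatic carbon of compound 3 gives a number 0.7 percentage points higher from compound 3 to compound 4 (within the scatter). Set beside the earlier step, the change shows no measurable difference between the two cores: the same change on two cores in this assay, a number 2.8 percentage points lower (within the scatter) from compound 1 to compound 2 and a number 0.7 percentage points higher (within the scatter) from compound 3 to compound 4, 3.5 percentage points apart, within the scatter of two such steps. This shows that the change from phenyl to 2-chlorophenyl stays within the scatter on both cores at the one concentration tested, but it does not show that the two steps are identical, and a smaller gap between them would go unseen.

The compounds shown leave open whether a methoxy or nitro group in place of the chloro would give a step beyond the scatter. They also leave open what free thiol groups in place of the acetyl and benzoyl groups on sulfur would give.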